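From compound 2 to compound 3: one added hydroxy

This account rests on a few compounds, and the source may have more. Where it says the series, first, only, none or still open, it means among the compounds named here.

Within the data shown here, in a toxicity assay (RAW264.7 cells) for cytotoxicity, with Mus musculus as the target, read by MTT assay, with a stated time of 4 h (a higher number here means a weaker inhibitor, a lower number a stronger inhibitor), compound 2 `O=c1oc2c(O)c(O)ccc2cc1-c1ccccc1` gives 26100 nM, the only actual number so far. Compound 1 `O=c1oc2c(O)cccc2cc1-c1cccc(O)c1` reports > 100000 nM, which is a limit of the assay and not a number. Compound 3 `O=c1oc2c(O)c(O)ccc2cc1-c1cccc(O)c1` is not yet measured and differs from compound 2 by hydroxy in place of hydrogen on an aromatic carbon. Among the measured compounds shown here, no measured pair isolates this change, so only a modest step toward weaker inhibition is expected in this assay. The expected step is a 1.5-fold higher number from compound 2 to compound 3 (0.19 log units; within the scatter). Compound 3 is estimated at 40000 nM, with an expected range of 15000 nM to 100000 nM.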

Compound 3, half-maximal inhibitory concentration: 398000 nM
Estimate against measurement, compound 3: 10-fold (1.00 log units) below; measured number above the stated range.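

In this assay, among these compounds, hydroxy in place of hydrogen on an aromatic carbon, meta to a large group, gives the only readable step: a 15-fold higher number from compound 2 to compound 3 (1.18 log units; beyond the scatter). This position therefore responds to the change, and the step runs toward weaker inhibition. Compound 1 stands at a limit of the assay, so its step to compound 3 cannot be read: the limit of > 100000 nM in this assay, at which 1 of the 3 values shown sits.

On these data alone, whether a methoxy, an amine or a carboxylic acid on the same carbon would give a step of similar size stays open. As far as these compounds go, whether this step holds on a core with other substituents also stays open.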